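The compounds below may be only part of what the source reports. "The series", "measured", "known", "first", "only" and "open" are said of these compounds alone.

Working notes on the series. Two analogues carry numbers in an ADME assay on microsomes from liver (Homo sapiens) for metabolic stability, tested at 2.5 uM; a higher number here means faster removal of the compound, a lower number slower removal. Compound 1 `COc1ccc(S(=O)(=O)c2cnc3cc(F)ccc3c2-c2cccc(F)c2)cc1Cl` gives 2.08 mL/min there. For the measured compounds named here, compound 2 `Cc1ccc(S(=O)(=O)c2cnc3cc(F)ccc3c2-c2cccc(Cl)c2)cc1C` gives 4.01 mL/min in this assay, the higher of the two numbers so far, though the gap to compound 1 is within the usual scatter, so the two are not separated.

The next compound, compound 3 `Cc1ccc(S(=O)(=O)c2cnc3cc(F)ccc3c2-c2cccc(F)c2)cc1C`, has not yet been measured in this assay. Relative to compound 2 the change is fluoro in place of chloro on an aromatic carbon.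

Going by the values given here, no measured pair isolates this change. Compound 1, which also carries the 3-fluorophenyl, gives 2.08 mL/min in this assay, but differs from compound 2 elsewhere as well, so it only hints at the direction. For compound 3 a step of a 1.3-fold lower number from compound 2 to compound 3 (0.13 log units; within the scatter) is expected, leaning slightly lower but not beyond the scatter. Compound 3 is therefore estimated at 3 mL/min, within 1.5 mL/min to 6 mL/min.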

Compound 3, intrinsic clearance in a liver preparation (reported as CLH), per the amount of preparation that the assay uses: 3.71 mL/min
The estimate for compound 3 lay 1.2-fold (0.09 log units) below the measured number, within the range that was stated.
By their numbers in this assay, from the lowest: compounds 1, 3 and 2 (each within the scatter of the next).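

In this assay, for the compounds shown here, the first pair that isolates this position reads a 1.1-fold lower number from compound 2 to compound 3 (0.03 log units; within the scatter) and so fluoro in place of chloro on this aromatic carbon, meta to a large group, does not separate the two compounds. The other new pair reads a 1.8-fold higher number from compound 1 to compound 3 (0.25 log units; within the scatter) and so 3,4-dimethylphenyl in place of 3-chloro-4-methoxyphenyl on a sulfonyl sulfur does not separate its two compounds either. Nothing at hand bears on either result.

The compounds shown leave open whether an amine or a carboxylic acid at this aromatic carbon would give a step beyond the scatter. They also leave open whether fluoro in place of chloro reads the same with 3-chloro-4-methoxyphenyl on the sulfonyl sulfur.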